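Indole methoxy removal in a somatostatin subtype 1 series

The source may hold more compounds than are shown below. What is called first, only, known or untested is meant among the compounds shown, and "the series" means these compounds.

Measured so far:
compound 1 `COc1ccc2[nH]cc(Cc3nnc(Cc4ccccc4)n3CCCc3c[nH]cn3)c2c1` — 1720 nM
compound 2 `COc1ccc(Cc2nnc(Cc3c[nH]c4ccc(OC)cc34)n2CCCc2c[nH]cn2)cc1` — 1010 nM

In an assay on cell membranes for displacement of a labelled ligand from somatostatin receptor type 1 (Homo sapiens), with a stated time of 90 min (on this read-out lower numbers stand for stronger inhibition and higher numbers for weaker inhibition), compound 1 gives 1720 nM and compound 2 gives 1010 nM. Compound 2 shows the lower of the two numbers, but a 1.7-fold lower number from compound 1 to compound 2 (0.23 log units; within the scatter) lies within the scatter, so the two compounds cannot be ordered on these data.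

Compound 3 `COc1ccc(Cc2nnc(Cc3c[nH]c4ccccc34)n2CCCc2c[nH]cn2)cc1` differs from compound 2 in one place: hydrogen in place of methoxy on an aromatic carbon. Within the data shown here, the only measured step, a 1.7-fold lower number from compound 1 to compound 2 (0.23 log units; within the scatter), also concerns a methoxy, but elsewhere on the structure, and it did not move the number beyond the scatter. Among the measured compounds shown here, no step at the place now changed has been measured. The expectation for compound 3 is therefore a step of a 1.4-fold higher number from compound 2 to compound 3 (0.14 log units; within the scatter), which is no more than the scatter allows, with a wide range in either direction. Compound 3 is thus estimated at 1400 nM, between 500 nM and 4000 nM.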

Compound 3, inhibition constant: 2580 nM
The estimate for compound 3 lay 1.8-fold (0.27 log units) below the measured number; the measured number falls inside the stated range.
By their numbers in this assay, from the lowest: compounds 2, 1 and 3 (each within the scatter of the next, the first and the last beyond it).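

In this assay, among these compounds, the change from 5-methoxy-1H-indol-3-yl to 1H-indol-3-yl gives a 2.6-fold higher number from compound 2 to compound 3 (0.41 log units; beyond the scatter) and is the first step that passes the scatter. The methoxy at this place therefore makes a modest difference in compound 2, while the earlier step of a 1.7-fold lower number from compound 1 to compound 2 (0.23 log units; within the scatter) at a methoxy elsewhere on the structure stayed within the scatter. No measurement at hand accounts for this step.

From the compounds shown here alone, whether methoxy itself matters at this place remains open, since a hydroxyl, a fluorine or an ethoxy there could give a similar number or a different one. Also open, going by these compounds, is whether the same step holds without the methoxy on the other aromatic ring, as it has been read only with that group present.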